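The source may report more compounds than this note shows. Statements on the series, on what has been measured and on what is new or still open speak of the compounds shown alone.

Measured so far:
- compound 1 `CN(C)CCC(=O)Nc1cncc(-c2cccc3[nH]ccc23)c1` — 300 nM in an assay for inhibition of Hematopoietic prostaglandin D synthase (Homo sapiens), read by fluorescence, with a stated time of 30 min; on this read-out lower numbers stand for stronger inhibition and higher numbers for weaker inhibition
- compound 2 `COCCCNC(=O)c1nc(-c2cccc3[nH]ccc23)no1` — 170 nM

Compound 1 gives the higher of the two numbers in this assay, but its gap to compound 2 lies within the scatter, so the two cannot be ordered.

Compound 3 `CCC(=O)Nc1cncc(-c2cccc3[nH]ccc23)c1` is not yet measured. It differs from compound 1 by hydrogen in place of dimethylamino on a saturated chain carbon, two bonds along the chain from a carbonyl carbon. Within the data shown here, no step of this kind has been measured, so there is nothing to set its size. The expectation is a step from compound 1 to compound 3 of a 1.8-fold higher number from compound 1 to compound 3 (0.26 log units; within the scatter), toward a higher number, of a size that may or may not exceed the scatter. The estimated value for compound 3 is 550 nM, between 180 nM and 1700 nM.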

Compound 3, half-maximal inhibitory concentration: 32 nM
Estimate against measurement, compound 3: 17-fold (1.24 log units) above; the whole stated range lies above it.
By their numbers in this assay, from the lowest: compound 3; then compounds 2 and 1 (each within the scatter of the next).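

In this assay, hydrogen in place of dimethylamino on a saturated chain carbon, two bonds along the chain from a carbonyl carbon, gives a 9.4-fold lower number from compound 1 to compound 3 (0.97 log units; beyond the scatter). This position is therefore sensitive to what it carries, and the dimethylamino group is not required for inhibition, since the simpler propanoyl compound 3 gives the lower number. Nothing at hand bears on the reason for this step.

As far as these compounds go, whether the step follows the loss of the amine nitrogen or of the carbon atoms with it remains open. A methoxy group at this carbon, or a longer unbranched chain, would help separate the two.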